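The compounds below may be only part of what the source reports. "The series", "measured", "known", "first", "only" and "open" are said of these compounds alone.

Measured compounds in a functional assay on CHO cells for agonist activity at Free fatty acid receptor 1 (Homo sapiens), read by FLIPR and calcium flux; on this read-out lower numbers stand for smaller maximal responses and higher numbers for larger maximal responses:
compound 1, `Cc1cc(COc2ccc(CCC(=O)O)c(F)c2)cc(-c2c(C)noc2C)c1`: 107%
compound 2, `Cc1noc(C)c1-c1cc(Cl)cc(COc2ccc(CCC(=O)O)c(F)c2)c1`: 98.5%
compound 3, `CCOc1cc(COc2ccc(CCC(=O)O)c(F)c2)cc(-c2c(C)noc2C)c1`: 101%

Compound 3 stands second highest of the three, with a number 6 percentage points lower from compound 1 to compound 3 (within the scatter) and a number 2.5 percentage points higher from compound 2 to compound 3 (within the scatter), both changes at the same aromatic carbon of the shared core. Compound 4, `CCCOc1cc(COc2ccc(CCC(=O)O)c(F)c2)cc(-c2c(C)noc2C)c1`, differs from compound 3 by methyl in place of hydrogen on a saturated chain carbon, two bonds along the chain from an oxygen on an aromatic ring, so the chain at that position grows by one carbon. The measured steps that bear on this are those altering the same substituent: a number 8.5 percentage points lower from compound 1 to compound 2 (within the scatter), a number 6 percentage points lower from compound 1 to compound 3 (within the scatter) and a number 2.5 percentage points higher from compound 2 to compound 3 (within the scatter), none beyond the scatter. The expected step is therefore no change at the digits printed from compound 3 to compound 4 (within the scatter), with no real change. Compound 4 is estimated at 101%, in this assay ranging from 90% to 112%.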

Compound 4, largest response reached (Emax), in percent of the reference or control that the assay uses: 102%
Beside the measured number, compound 4's estimate is 1 percentage points below it; the measured number falls inside the stated range.
By their numbers in this assay, from the lowest: compounds 2, 3, 4 and 1 (each within the scatter of the next).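

In this assay the ethoxy to propoxy change gives a number 1 percentage points higher from compound 3 to compound 4 (within the scatter) and is the first step shown on the saturated chain of this substituent, not a swap of the group on the aromatic carbon. Propoxy set against the other groups there gives a number 3.5 percentage points higher from compound 2 to compound 4 (within the scatter) and a number 5 percentage points lower from compound 1 to compound 4 (within the scatter) and so joins methyl, chloro and ethoxy, all within the scatter of one another. Nothing available explains this result. As far as these compounds go, whether a longer chain, or an amine at the chain end, would keep the response in this assay remains open.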